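This account rests on a few compounds, and the source may have more. Where it says the series, first, only, none or still open, it means among the compounds named here.

Series in a physicochemical assay for solubility, read by HPLC, in phosphate buffer, measured as kinetic solubility, at pH 7.4; a higher number here means a more soluble compound, a lower number a less soluble compound:
- compound 1 `CCC(=O)c1cc(-c2ccc(S(N)(=O)=O)cc2)nn1-c1ccc(Cl)cc1`: 49600 nM
- compound 2 `CN(C)C(=O)c1cc(-c2ccc(S(N)(=O)=O)cc2)nn1-c1ccc(Cl)cc1`: 5200 nM
- compound 3 `CN(C(=O)c1cc(-c2ccc(S(N)(=O)=O)cc2)nn1-c1ccc(Cl)cc1)C1CC1`: not yet measured

In this assay compound 2, at 5200 nM, holds the lower number of the two measured compounds. The change leading to compound 3 is cyclopropyl in place of methyl on an amide-type nitrogen. For the measured compounds named here, only one measured step bears on this, and only loosely: a 9.5-fold lower number from compound 1 to compound 2 (0.98 log units; beyond the scatter). Going by the values given here, that modest step is a change on a carbonyl carbon, and no measured step covers a change on the amide-type nitrogen. The direction of that one step gives a weak lean towards a lower number, and its size is no guide. The expected outcome is a 1.5-fold lower number from compound 2 to compound 3 (0.17 log units; within the scatter), a small step that stays within the scatter. Compound 3 is estimated at 3500 nM, with an expected range of 1200 nM to 10000 nM.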

Compound 3, solubility: 8000 nM
Beside the measured number, compound 3's estimate is 2.3-fold (0.36 log units) below it; the measured number falls inside the stated range.
By their numbers in this assay, from the lowest: compounds 2 and 3 (each within the scatter of the next); then compound 1.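

In this assay, cyclopropyl in place of methyl on the amide-type nitrogen gives a 1.5-fold higher number from compound 2 to compound 3 (0.19 log units; within the scatter), so this first measured change at the position leaves compound 2 and compound 3 not distinguishable. The gap opened by replacing ethyl on the carbonyl carbon persists with cyclopropyl(methyl)amino, at a 6.2-fold lower number from compound 1 to compound 3 (0.79 log units; beyond the scatter), and so does not depend on the dimethylamino group alone. No measurement available here accounts for either step.

Still open, from the compounds shown here alone, is whether any group on this nitrogen moves the number beyond the scatter from compound 2: a longer chain, a hydroxyethyl group or a chain ending in an amine would test this. Also open, going by these compounds, is what the amide hydrogen in place of methyl would give.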